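Swapping an Aryl Thioether for a Phenethyl Thioether

The source may hold more compounds than are shown below. What is called first, only, known or untested is meant among the compounds shown, and "the series" means these compounds.

Measured so far:
- compound 1 `COc1ccc(SCc2ccc(C(=O)Nc3ccccc3N)cc2)cc1`: 2570 nM
- compound 2 `Nc1ccccc1NC(=O)c1ccc(CSc2ccc(F)cc2)cc1`: "not determined" (no result reported)
- compound 3 `Nc1ccccc1NC(=O)c1ccc(CSc2ccc(Cl)cc2)cc1`: "not determined" (no result reported)

The compounds share one core, an amide bearing a 2-aminophenyl group on one side and a benzyl thioether on the other, and differ only in the group attached to the sulfur. In a functional assay on A549 cells (Homo sapiens) for antiproliferative activity, read by CCK-8 assay, with a stated time of 72 h (a lower number here means a stronger inhibitor, a higher number a weaker inhibitor), compound 1 gives 2570 nM. For compound 2 the entry in this assay reads "not determined" (no result reported). For compound 3 the entry in this assay reads "not determined" (no result reported), so compound 3 stands without any measured value, and the only anchor in this series is compound 1.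

Compound 4 `Nc1ccccc1NC(=O)c1ccc(CSCCc2ccccc2)cc1` is the next compound. Relative to compound 3 the change is phenethyl in place of 4-chlorophenyl on a sulfur. For the measured compounds named here, no measured step exists between any two compounds here, so nothing shows how a change on the sulfur moves the result. The expectation for compound 4 therefore rests on compound 1 alone: a value of similar size, with no direction beyond the scatter assumed. In this assay compound 4 is expected to give about 3000 nM, plausibly between 800 nM and 12000 nM.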

Compound 4, half-maximal inhibitory concentration: 3250 nM
Compound 4: the middle estimate sits 1.1-fold (0.03 log units) below what was measured; low and high end bracket the measured number.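

Phenethyl in place of 4-methoxyphenyl on a sulfur is the first change at this position that can be read, and in this assay it gives a 1.3-fold higher number from compound 1 to compound 4 (0.10 log units; within the scatter) with the rest of the molecule unchanged. The position therefore accepts either an aromatic ring bonded directly to the sulfur or a phenethyl group with no difference beyond the scatter, while steps involving compound 2 or compound 3 cannot be read. No measurement here offers an explanation for this result.

The compounds shown leave open whether the same holds for an amine, a carboxylic acid or a chain longer than phenethyl on the sulfur. They also do not show whether any change at this position can move the number beyond the scatter.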